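The source may report more compounds than this note shows. Statements on the series, on what has been measured and on what is new or still open speak of the compounds shown alone.

Measured so far in a functional assay on MDA-MB-435 cells (Homo sapiens) for cytotoxicity, read by sulforhodamine B assay, with a stated time of 48 h, tested at 100 uM; a higher number here means a weaker effect of the compound at the concentration tested, a lower number a stronger effect:
compound 1 `COc1cc(-c2cc(/C=C/C(=O)c3ccc(N)cc3)[nH]n2)cc(OC)c1OC` — -85%
compound 2 `COc1ccc(-c2cc(/C=C/C(=O)c3cc(OC)c(OC)c(OC)c3)[nH]n2)cc1OC` — -78%

In this assay compound 1 gives -85% and compound 2 gives -78%; the two readings lie within the scatter of each other, so neither can be set above the other, and compound 1 simply carries the lower of the two numbers.

Compound 3 `COc1cc(-c2cc(/C=C/C(=O)c3ccc(F)c(F)c3)[nH]n2)cc(OC)c1OC` is not yet measured. It differs from compound 1 by 3,4-difluorophenyl in place of 4-aminophenyl on a carbonyl carbon. Among the measured compounds shown here, no pair of measured compounds shows the effect of exchanging the group on the carbonyl carbon, so the direction of the step cannot be read from the data. A step of a number 15 percentage points higher from compound 1 to compound 3 (beyond the scatter) of modest size toward a weaker effect is expected, not clearly beyond the scatter. Compound 3 is estimated to give -70%, expected to fall between -95% and -30%.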

Compound 3, a percentage reported as activity, at one concentration (the size of the read-out at that concentration, not a potency): -34%
The estimate for compound 3 lay 36 percentage points below the measured number; low and high end bracket the measured number.
By their numbers in this assay, from the lowest: compounds 1 and 2 (each within the scatter of the next); then compound 3.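

In this assay, the group on the carbonyl carbon proves to be a place where a single exchange matters: 3,4-difluorophenyl in place of 4-aminophenyl gives a number 51 percentage points higher from compound 1 to compound 3 (beyond the scatter), a large step toward a weaker effect with the rest of the structure unchanged. The reading of compound 3 is still negative at -34%, so the effect is weakened but the 4-aminophenyl group is not required for a negative reading. Nothing measured on these compounds explains the step.

From the compounds shown here alone, whether the step follows the loss of the amine or the entry of the two fluorines stays open, as this single exchange changes both at once. Also open, going by these compounds, is how an unsubstituted phenyl, or an acetamide in place of the amine, would read in this assay.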